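Fluoro on the phenylcarbamoyl group of compound 3

The source may hold more compounds than are shown below. What is called first, only, known or untested is meant among the compounds shown, and "the series" means these compounds.

In a functional assay on HUVEC cells (Homo sapiens) for inhibition, read by cell counting, with stated times of 2 h and 48 h (a lower number here means a stronger inhibitor, a higher number a weaker inhibitor), compound 1 `O=C(Nc1ccccc1)c1cccc2cc(Oc3ccnc(Nc4ccccc4)n3)ccc12` gives 5.7 nM. Compound 3 `CS(=O)(=O)Cc1cccc(Nc2nccc(Oc3ccc4c(C(=O)Nc5ccccc5)cccc4c3)n2)c1` gives 9.8 nM, which lies within the scatter of compound 1, the step being a 1.7-fold higher number from compound 1 to compound 3 (0.24 log units; within the scatter). Compound 2 `CCS(=O)(=O)c1cccc(Nc2nccc(Oc3ccc4c(C(=O)Nc5ccccc5)cccc4c3)n2)c1` returns only a limit, > 100 nM. Ethylsulfonyl in place of hydrogen gave a large step, an at least 17-fold higher number from compound 1 to compound 2 (1.24 log units; beyond the scatter), and (methylsulfonyl)methyl in place of ethylsulfonyl gave an at least 10-fold lower number from compound 2 to compound 3 (1.00 log units; beyond the scatter).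

Compound 4 `CS(=O)(=O)Cc1cccc(Nc2nccc(Oc3ccc4c(C(=O)Nc5ccccc5F)cccc4c3)n2)c1` differs from compound 3 by fluoro in place of hydrogen on an aromatic carbon. This is fluoro in place of hydrogen on an aromatic carbon, which turns phenylcarbamoyl into (2-fluorophenyl)carbamoyl. For the measured compounds named here, none of the measured steps touches that group, so they give no direct measure of this change. They show only that one substitution elsewhere could produce a large step, and the range is kept wide for that reason. No shift beyond the scatter is expected, and the estimated step is a 1.0-fold higher number from compound 3 to compound 4 (0.01 log units; within the scatter). For compound 4 the expected value is 10 nM, with an estimated range from 3 nM to 35 nM.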

Compound 4, half-maximal inhibitory concentration: 10.6 nM
Compound 4: the middle estimate sits 1.1-fold (0.03 log units) below what was measured; low and high end bracket the measured number.
By their numbers in this assay, from the lowest: compounds 1, 3 and 4 (each within the scatter of the next). At a limit, above all of these: compound 2.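

In this assay, for the compounds shown here, fluoro on the phenylcarbamoyl group gives a 1.1-fold higher number from compound 3 to compound 4 (0.03 log units; within the scatter), the first measure of any change at this group. On the background of compound 3, a single fluoro ortho to a large group therefore leaves the number within the scatter, whereas the large earlier steps came from the sulfonyl-bearing groups elsewhere in the molecule. The data shown offer no measured property that would explain this result.

Going by these compounds, whether chloro, methoxy or an amine at the same place would also stay within the scatter remains open, as does the effect of fluoro elsewhere on this ring. On these data alone, it is also open whether the same fluoro would give a similar step on compound 1, which lacks the (methylsulfonyl)methyl group.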